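The source may report more compounds than this note shows. Statements on the series, on what has been measured and on what is new or still open speak of the compounds shown alone.

Of the compounds shown here, three sharing one core have been measured in a functional assay on A549 cells (Homo sapiens) for cytotoxicity, read by MTT assay, with a stated time of 48 h; on this read-out higher numbers stand for weaker inhibition and lower numbers for stronger inhibition. Compound 1 `COc1cc(-c2nnc3n2NC(c2cccs2)C(C(=O)c2ccccc2)S3)cc(OC)c1OC` gives 69400 nM. Compound 2 `COc1cc(-c2nnc3n2NC(c2cccs2)C(C(=O)c2ccc(C)cc2)S3)cc(OC)c1OC`, carrying methyl in place of hydrogen on an aromatic carbon, gives 12700 nM, and that single change produced a 5.5-fold lower number from compound 1 to compound 2 (0.74 log units; beyond the scatter). Compound 3 `COc1cc(-c2nnc3n2NC(c2ccco2)C(C(=O)c2ccco2)S3)cc(OC)c1OC` gives 68700 nM. On these numbers compound 3 stands second highest of the three: its number and that of compound 1 lie within the scatter of each other, while compound 2 sits lower, beyond the scatter.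

Compound 4 `COc1cc(-c2nnc3n2NC(c2ccco2)C(C(=O)c2cccc(Br)c2)S3)cc(OC)c1OC` has not yet been measured. It differs from compound 3 in one place: 3-bromophenyl in place of furan-2-yl on a carbonyl carbon. Among the compounds with values here, no measured step matches this change exactly. Compound 1 and compound 3 differ in two places, so their near-equal numbers offer only a hint that the ring on the carbonyl carbon by itself moves the number little. Within the data shown here, the one measured step, a 5.5-fold lower number from compound 1 to compound 2 (0.74 log units; beyond the scatter), shows that a small addition on the aromatic ring attached to the carbonyl went with a clearly lower number, and compound 4 likewise gains a substituent on that ring. Compound 4 is therefore expected to show a 2.3-fold lower number from compound 3 to compound 4 (0.36 log units; beyond the scatter), a modest move downwards. The estimated value for compound 4 in this assay is 30000 nM, with a likely range from 8000 nM to 100000 nM.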

Compound 4, half-maximal inhibitory concentration: 36900 nM
For compound 4 the middle estimate is 1.2-fold (0.09 log units) below the measured one; the range from low to high includes it.
By their numbers in this assay, from the lowest: compound 2; then compounds 4, 3 and 1 (each within the scatter of the next).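

In this assay, putting 3-bromophenyl in place of furan-2-yl on the carbonyl carbon gives a 1.9-fold lower number from compound 3 to compound 4 (0.27 log units; within the scatter), so on this read-out the two groups cannot be told apart at this position, even though a five-membered aromatic ring with one hetero atom gives way to a six-membered aromatic ring of carbon only that also carries bromine. This is the first comparison shown in which the whole ring on the carbonyl carbon is replaced and only that place differs, and it stays within the scatter, whereas the smaller change of methyl in place of hydrogen on an aromatic carbon gave a 5.5-fold lower number from compound 1 to compound 2 (0.74 log units; beyond the scatter) on a different pair of compounds. Nothing available explains either result.

The compounds shown leave open what the bromine contributes on its own and what the exchange of one ring for the other contributes, as the single step from furan-2-yl to 3-bromophenyl carries both differences at once. Going by these compounds, it also remains open how this position responds to a quite different group, such as an amine or a carboxylic acid on the ring attached to the carbonyl carbon.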